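The source may report more compounds than this note shows. Statements on the series, on what has been measured and on what is new or still open speak of the compounds shown alone.

Compound 1 `Cc1cccc(-c2cc(Cl)cc(Cl)c2/C=C/[C@@H]2C[C@@H](O)CC(=O)O2)c1`: 16 nM
Compound 2 `Cc1cc(C)c(/C=C/[C@@H]2C[C@@H](O)CC(=O)O2)c(-c2ccc(F)cc2)c1`: 13 nM
Compound 3 `Cc1cc(C)c(/C=C/[C@@H]2C[C@@H](O)CC(=O)O2)c(-c2cc(C)c(F)c(C)c2)c1`: 10 nM

In an assay for inhibition of 3-hydroxy-3-methylglutaryl-coenzyme A reductase (Rattus norvegicus) (on this read-out lower numbers stand for stronger inhibition and higher numbers for weaker inhibition), compound 1 gives 16 nM, the highest of the three numbers. Compound 2 gives 13 nM in this assay, and compound 3 gives 10 nM; both of these numbers lie within the scatter of the number for compound 1, so the three measured compounds cannot be told apart on this read-out.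

Going by the values given here, only one measured step joins two compounds that differ in a single place: a 1.3-fold lower number from compound 2 to compound 3 (0.11 log units; within the scatter). Adding two methyl groups to the pendant ring thus left this assay unchanged beyond the scatter.

Compound 4 `CCc1cccc(-c2cc(Cl)cc(Cl)c2/C=C/[C@@H]2C[C@@H](O)CC(=O)O2)c1` differs from compound 1 by methyl in place of hydrogen on a saturated chain carbon bound to an aromatic carbon. Among the compounds with values here, no measured step changes the same position; the nearest precedent is the step from compound 2 to compound 3, which also enlarged a substituent on the pendant ring and stayed within the scatter. On that basis no step beyond the scatter is expected in this assay. Compound 4 is therefore estimated at 15 nM, with a range of 7 nM to 32 nM, which would amount to a 1.1-fold lower number from compound 1 to compound 4 (0.03 log units; within the scatter).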

Compound 4, half-maximal inhibitory concentration: 44 nM
For compound 4 the middle estimate is 2.9-fold (0.47 log units) below the measured one, outside the stated range (above it).
By their numbers in this assay, from the lowest: compounds 3, 2 and 1 (each within the scatter of the next); then compound 4.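

In this assay, the change from 3-methylphenyl to 3-ethylphenyl, methyl in place of hydrogen on a saturated chain carbon bound to an aromatic carbon, gives a 2.8-fold higher number from compound 1 to compound 4 (0.44 log units; beyond the scatter), a modest step but the only one shown that lies beyond the scatter. It shows that this position does not tolerate every enlargement equally: a single added carbon is enough to register here, whereas the earlier step, a 1.3-fold lower number from compound 2 to compound 3 (0.11 log units; within the scatter), at a different place on a different core, gave no such signal and could not have revealed this. Nothing at hand accounts for the size or direction of this step.

The compounds shown leave open whether the number keeps rising with a longer chain such as propyl, or whether a branched group such as isopropyl, or a methoxy group or an amine in the same place, would behave like ethyl or like methyl. They also leave open whether 3-ethylphenyl would produce a comparable step on the core of compound 2, so the finding rests on this single pair.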